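Replacing the Fluorophenyl Group on the Core Nitrogen

The compounds below may be only part of what the source reports. "The series", "measured", "known", "first", "only" and "open" are said of these compounds alone.

Compound 1 `Sc1nnc(COc2ccc(-c3ccccc3)cc2)n1-c1ccc(Br)cc1` gives 31.8% in a functional assay on the whole organism (strain Wistar) for inhibition, with Rattus norvegicus as the target, read by paw edema, with a stated time of 3 h, at a dose of 10 mg/kg by the oral route; a higher number here means more inhibition at the dose given (going by the name of the read-out), a lower number less inhibition.
Compound 2 `Fc1ccc(-n2c(S)nnc2COc2ccc(-c3ccccc3)cc2)cc1` gives 75% in this assay.

Among the measured compounds shown here, compound 2 stands highest of the two numbers, and the only measured step, a number 43.2 percentage points higher from compound 1 to compound 2 (beyond the scatter), is large. Compound 3 `Cc1ccc(-n2c(S)nnc2COc2ccc(-c3ccccc3)cc2)c(C)c1` differs from compound 2 by 2,4-dimethylphenyl in place of 4-fluorophenyl on an aromatic nitrogen. For the measured compounds named here, that single step shows only that changing the group at this position can move the read-out a great deal; it gives no direction for a dimethylphenyl group, so the estimate is uncertain. The expected step is a number 25 percentage points lower from compound 2 to compound 3 (beyond the scatter). Compound 3 is therefore expected to give about 50%, within 25% to 75%.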

Compound 3, a percentage reported as inhibition, in the whole organism at one dose (the size of the read-out at that dose, not a potency): 54.5%
Beside the measured number, compound 3's estimate is 4.5 percentage points below it, within the range that was stated.
By their numbers in this assay, from the lowest: compound 1; then compound 3; then compound 2.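

Putting 2,4-dimethylphenyl on the aromatic nitrogen in place of 4-fluorophenyl gives a number 20.5 percentage points lower from compound 2 to compound 3 (beyond the scatter) in this assay, while putting it in place of 4-bromophenyl gives a number 22.7 percentage points higher from compound 1 to compound 3 (beyond the scatter). So a ring carrying two methyl groups and no halogen keeps a good part of the inhibition, and the three groups at this position give three clearly separate numbers. Nothing measured here explains these differences.

Still open, going by these compounds, is how a plain phenyl ring would read here, and whether a single methyl accounts for the number. An amine or a longer chain at this position also remains untested ground in the compounds shown.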